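The compounds below may be only part of what the source reports. "The series", "measured", "known", "first", "only" and "open" are said of these compounds alone.

Of the compounds shown here, three sharing one core have been measured in a functional assay on the whole organism (strain Kunming) with Mus musculus as the target, in the formalin test, with a stated time of 0.5 h (a higher number here means that more compound is needed for the effect, a lower number that less compound is needed), and their numbers lie close together. Compound 1 `COc1cc(OC)c(OC)cc1/C=C/COC(=O)/C=C/c1ccc(Br)cc1` gives 105 mg/kg and compound 2 `COc1cc(OC)c(OC)cc1/C=C/COC(=O)/C=C/c1ccccc1C(F)(F)F` gives 123 mg/kg while compound 3 `COc1cc(OC)c(OC)cc1/C=C/COC(=O)/C=C/c1cccc(Br)c1` gives 113 mg/kg on the same read-out. Compound 3 therefore stands level with the other two, within the scatter of each. The measured steps are a 1.1-fold higher number from compound 1 to compound 3 (0.03 log units; within the scatter) and a 1.1-fold lower number from compound 2 to compound 3 (0.04 log units; within the scatter) and also a 1.2-fold higher number from compound 1 to compound 2 (0.07 log units; within the scatter) and all three change only the group on a double-bonded chain carbon bound to a double-bonded chain carbon. Compound 4 `COc1ccc(/C=C/C(=O)OC/C=C/c2cc(OC)c(OC)cc2OC)cc1` keeps the shared core and differs from compound 3 by 4-methoxyphenyl in place of 3-bromophenyl on a double-bonded chain carbon bound to a double-bonded chain carbon and so alters that same place. Among the compounds with values here, none of the measured compounds carries 4-methoxyphenyl, so the data give no direct reading for this group, and the three steps bear on it only as a guide to how much a swap here has moved the number so far. With compound 3 at 113 mg/kg and its steps to both others inside the scatter, no step beyond the scatter is expected in this assay and no direction can be argued. The estimated step is a 1.0-fold lower number from compound 3 to compound 4 (0.01 log units; within the scatter) and it is expected to stay inside the scatter. For compound 4 the estimate is 110 mg/kg with 70 mg/kg to 170 mg/kg as the expected range.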

Compound 4, dose for half-maximal effect: 122 mg/kg
Estimate against measurement, compound 4: 1.1-fold (0.04 log units) below; measured number inside the range.
By their numbers in this assay, from the lowest: compounds 1, 3, 4 and 2 (each within the scatter of the next).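

With 4-methoxyphenyl, the place on a double-bonded chain carbon bound to a double-bonded chain carbon now holds a group with one hydrogen-bond acceptor by count, where 3-bromophenyl has none, and this assay still shows no step beyond the scatter: a 1.1-fold higher number from compound 3 to compound 4 (0.03 log units; within the scatter) and a 1.0-fold lower number from compound 2 to compound 4 (0.00 log units; within the scatter). The swap of methoxy in place of bromo on an aromatic carbon gives a 1.2-fold higher number from compound 1 to compound 4 (0.07 log units; within the scatter), so this direct exchange on the ring also stays within the scatter, and the flat reading now extends from the bromo and trifluoromethyl compounds to one carrying methoxy. No measurement is at hand that could explain this flat reading.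

The four compounds leave open whether any group at this place can move the number beyond the scatter, for example a phenyl ring bearing an amine or a carboxylic acid, or a saturated ring such as cyclohexyl in place of the phenyl. They also leave open how much the shared core itself matters, for instance with an amide in place of the ester or with fewer methoxy groups on the other ring.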